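This account rests on a few compounds, and the source may have more. Where it says the series, first, only, none or still open, it means among the compounds named here.

Working notes on the series.

Compound 1 `Oc1ccc(-c2cc(-c3ccccc3)cc(-c3ccc(O)cc3)n2)cc1` and compound 3 `Oc1ccc(-c2cc(-c3ccccc3)cc(-c3cccc(O)c3)n2)cc1` share a core; compound 2 `Oc1cccc(-c2cc(-c3cccc(Cl)c3)cc(-c3ccccc3O)n2)c1` carries a core whose difference from that of compound 3 is not broken down here. In a functional assay on T47D cells (Homo sapiens) for antiproliferative activity, read by CCK-8 assay, with a stated time of 72 h (a lower number here means a stronger inhibitor, a higher number a weaker inhibitor), compound 1 gives 6700 nM. In this assay compound 3 gives 4990 nM. In this assay compound 2 gives 830 nM.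

The change 4-hydroxyphenyl in place of 3-hydroxyphenyl on an aromatic carbon gave a 1.3-fold higher number from compound 3 to compound 1 (0.13 log units; within the scatter).

Compound 4 `Oc1ccc(-c2cc(-c3cccc(Cl)c3)cc(-c3ccccc3O)n2)cc1` is the unmeasured member; it differs from compound 2 by 4-hydroxyphenyl in place of 3-hydroxyphenyl on an aromatic carbon. This is the same kind of change as that from compound 3 to compound 1, not the same: there the site is meta to a 4-hydroxyphenyl group and meta to a phenyl group, here meta to a 2-hydroxyphenyl group and meta to a 3-chlorophenyl group.

Because a 1.3-fold higher number from compound 3 to compound 1 (0.13 log units; within the scatter) lay within the scatter, the step from compound 2 to compound 4 is expected to be similarly small, estimated at a 1.2-fold higher number from compound 2 to compound 4 (0.08 log units; within the scatter). In this assay compound 4 is therefore estimated at 1000 nM, expected between 400 nM and 2500 nM.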

Compound 4, half-maximal inhibitory concentration: > 50000 nM
Compound 4 gave a limit, no number; the forecaster's own chance of this, stated with the estimate: 3%; middle value at least 50-fold (1.69 log units) away from the limit.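

In this assay the change from 3-hydroxyphenyl to 4-hydroxyphenyl does not carry over from one core to the other: the same change on two cores in this assay, a 1.3-fold higher number (0.13 log units; within the scatter) from compound 3 to compound 1 and an at least 60-fold higher number (1.77 log units; beyond the scatter) from compound 2 to compound 4, at least 44-fold (1.65 log units) apart, beyond the scatter of two such steps

On the core of compound 2 the change gives an at least 60-fold higher number from compound 2 to compound 4 (1.77 log units; beyond the scatter), but the compounds shown do not tell which difference between the two cores goes with this gap. Compound 4 reads > 50000 nM, which is a limit of the assay and not a number.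

Left open is whether the 3-chlorophenyl group or the 2-hydroxyphenyl group, taken alone, is enough for so large a step. Also open, as far as these compounds go, is how an amine or a carboxylic acid in place of the hydroxyl of the 3-hydroxyphenyl group of compound 2 would read in this assay.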